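Phenyl for vinyl at the amine chain carbon

The source may report more compounds than this note shows. Statements on the series, on what has been measured and on what is new or still open speak of the compounds shown alone.

Measured so far:
compound 1 `CCCN1CCC(c2noc(COc3ccc(CCC(=O)NO)cc3)n2)CC1` — 13%
compound 2 `C=CCN1CCC(c2noc(COc3ccc(CCC(=O)NO)cc3)n2)CC1` — 15%

In an assay on isolated protein for inhibition of protein deacetylase HDAC6 (Homo sapiens), read by fluorescence, with a stated time of 1 h, tested at 100 nM (on this read-out higher numbers stand for more inhibition at the one concentration tested (going by the name of the read-out) and lower numbers for less inhibition), compound 1 gives 13% and compound 2 gives 15%. The step of a number 2 percentage points higher from compound 1 to compound 2 (within the scatter) keeps the two values within the scatter, so compound 2 stands level with compound 1 on this assay. Compound 3 `O=C(CCc1ccc(OCc2nc(C3CCN(Cc4ccccc4)CC3)no2)cc1)NO` differs from compound 2 by phenyl in place of vinyl on a saturated chain carbon bound to an amine nitrogen in a ring. For the measured compounds named here, the only measured step at this place, a number 2 percentage points higher from compound 1 to compound 2 (within the scatter), changed nothing beyond the scatter, and no step with phenyl entering exists, so the phenyl change has no direct precedent. The step to compound 3 is expected to be a number 5 percentage points higher from compound 2 to compound 3 (within the scatter). Compound 3 is estimated at 20% in this assay, with a range of 5% to 40%.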

Compound 3, a percentage reported as inhibition, at one concentration (the size of the read-out at that concentration, not a potency): 22%
The estimate for compound 3 lay 2 percentage points below the measured number; the measured number falls inside the stated range.
By their numbers in this assay, from the lowest: compounds 1, 2 and 3 (each within the scatter of the next).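

In this assay, phenyl in place of vinyl gives a number 7 percentage points higher from compound 2 to compound 3 (within the scatter), and phenyl in place of ethyl gives a number 9 percentage points higher from compound 1 to compound 3 (within the scatter). A six-membered aromatic ring of carbon only at this saturated chain carbon therefore leaves compound 3 level with compound 1 and compound 2, so the larger group does not separate the three. No evidence is available to explain this result. Open, on these data alone, is whether pyridine in place of phenyl, a carboxylic acid on the phenyl, or a longer chain carrying the phenyl would give a step beyond the scatter.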